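Enlarging the Branched Substituent on the Shared Core

The source may report more compounds than this note shows. Statements on the series, on what has been measured and on what is new or still open speak of the compounds shown alone.

Measured so far:
compound 1 `CCCn1c(=O)c2nc(C(C)C)[nH]c2n(CCC)c1=O`: 49 nM
compound 2 `CCCn1c(=O)c2nc(C(CC)CC)[nH]c2n(CCC)c1=O`: 19 nM

In an assay on cell membranes for binding affinity to adenosine receptor A1 (Cavia porcellus) (on this read-out lower numbers stand for stronger inhibition and higher numbers for weaker inhibition), compound 2 gives 19 nM, the lowest of the two numbers; nearest is compound 1, with a 2.6-fold lower number from compound 1 to compound 2 (0.41 log units; beyond the scatter). Compound 3 `CCCn1c(=O)c2nc(C(CC)Oc3ccccc3)[nH]c2n(CCC)c1=O` is unmeasured; it carries phenoxy in place of ethyl on a saturated chain carbon bound to an aromatic carbon and a saturated chain carbon. Going by the values given here, only one step bears on this, the modest gain from enlarging the same branch in a 2.6-fold lower number from compound 1 to compound 2 (0.41 log units; beyond the scatter); the entering group is far larger than anything measured, so that step is a weak guide. For compound 3 a step of a 1.4-fold lower number from compound 2 to compound 3 (0.13 log units; within the scatter) in this assay is expected, a small gain at most. Compound 3 is estimated at 14 nM, range 4 nM to 60 nM.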

Compound 3, inhibition constant: 900 nM
For compound 3 the middle estimate is 64-fold (1.81 log units) below the measured one; the measured number lies above the stated range.
By their numbers in this assay, from the lowest: compound 2; then compound 1; then compound 3.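

In this assay, going by these compounds alone, phenoxy in place of ethyl on this saturated chain carbon brings a 47-fold higher number from compound 2 to compound 3 (1.68 log units; beyond the scatter) and marks a sharp loss at a position that had so far only gained. The earlier gain, a 2.6-fold lower number from compound 1 to compound 2 (0.41 log units; beyond the scatter), therefore sets no general rule for enlarging this branch, and compound 3 goes against it. Nothing measured here accounts for the loss. Still open, as far as these compounds go, is whether the loss follows the oxygen or the phenyl ring; a benzyl group or a methoxy group on the same carbon would separate the two.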